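From Vinyl to Bromomethyl on One Short Chain

The compounds below may be only part of what the source reports. "The series", "measured", "known", "first", "only" and "open" are said of these compounds alone.

Compound 1 `BrCCCCOc1c(Br)cc(Br)cc1Oc1ccc(Br)cc1Br`: 25.9 ug/mL
Compound 2 `C=CCOc1c(Br)cc(Br)cc1Oc1ccc(Br)cc1Br`: 27.9 ug/mL

Going by the values given here, in a functional assay on HL-60 cells (Homo sapiens) for cytotoxicity, read by MTT assay, with a stated time of 24 h (on this read-out higher numbers stand for weaker inhibition and lower numbers for stronger inhibition), compound 2 stands level with compound 1, its only measured neighbour. Among the compounds with values here, the one measured step, a 1.1-fold higher number from compound 1 to compound 2 (0.03 log units; within the scatter), exchanged 3-bromopropyl for vinyl on the same chain carbon and stayed within the scatter. Compound 3 `BrCCOc1c(Br)cc(Br)cc1Oc1ccc(Br)cc1Br` brings a similar exchange in reverse: bromomethyl in place of vinyl on a saturated chain carbon bound to an oxygen on an aromatic ring, so bromomethyl in place of vinyl, which also reads as allyl to 2-bromoethyl. Within the data shown here, with that measured step as the only guide, no change beyond the scatter is expected. The expected step is a 1.1-fold lower number from compound 2 to compound 3 (0.03 log units; within the scatter). For compound 3 the estimated value is 26 ug/mL, with an expected range of 15 ug/mL to 45 ug/mL.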

Compound 3, half-maximal inhibitory concentration: 26.2 ug/mL
For compound 3 the middle estimate is 1.0-fold (0.00 log units) below the measured one, within the range that was stated.
By their numbers in this assay, from the lowest: compounds 1, 3 and 2 (each within the scatter of the next).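

In this assay, the step with bromomethyl in place of vinyl, a 1.1-fold lower number from compound 2 to compound 3 (0.03 log units; within the scatter), shows that this exchange leaves the number level. The two bromine-bearing chains also read alike, with a 1.0-fold higher number from compound 1 to compound 3 (0.01 log units; within the scatter), so all three groups at this position now lie within the scatter of one another. No available evidence explains why the numbers stay level.

Still open, going by these compounds, is whether an amine or a carboxylic acid on this chain would move the number beyond the scatter.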